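Methylsulfonyl Replaces (3,5-Dichlorophenyl)carbonyl: Expected Inhibition

A few compounds are considered here, and "the series" means these few. Any claim that something is new, unique, unknown or untested is made for them only; others in the source may bear on it.

Compound 1 `CN(C)c1ccc(C2CC(c3ccc(-n4cncn4)cc3)=NN2C(=O)c2ccc(F)cc2)cc1`: 12.5%
Compound 2 `CN(C)c1ccc(C2CC(c3ccc(-n4cncn4)cc3)=NN2C(=O)c2cc(Cl)cc(Cl)c2)cc1`: 9.4%

In a functional assay on MDA-MB-231 cells (Homo sapiens) for inhibition, read by sulforhodamine B assay, tested at 10 uM (a lower number here means less inhibition, a higher number more inhibition at the concentration tested (going by the name of the read-out)), compound 2 gives 9.4% and compound 1 gives 12.5%; these two numbers are within the scatter of each other, as the step of a number 3.1 percentage points lower from compound 1 to compound 2 (within the scatter) shows. Compound 3 `CN(C)c1ccc(C2CC(c3ccc(-n4cncn4)cc3)=NN2S(C)(=O)=O)cc1` carries a different change: methylsulfonyl in place of (3,5-dichlorophenyl)carbonyl on an amine nitrogen in a ring. For the measured compounds named here, the one measured step exchanges only the aryl on the carbonyl, so nothing measured bears on this change. The expected step is therefore a number 0.6 percentage points higher from compound 2 to compound 3 (within the scatter), none beyond the scatter. Compound 3 is estimated at 10%, within 0% to 25%.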

Compound 3, a percentage reported as inhibition, at one concentration (the size of the read-out at that concentration, not a potency): 7.8%
Estimate against measurement, compound 3: 2.2 percentage points above; low and high end bracket the measured number.
By their numbers in this assay, from the lowest: compounds 3, 2 and 1 (each within the scatter of the next).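

On the amine nitrogen in the ring, methylsulfonyl, with no ring and fewer heavy atoms, takes the place of the whole (3,5-dichlorophenyl)carbonyl (a number 1.6 percentage points lower from compound 2 to compound 3 (within the scatter)) in this assay, and it takes the place of (4-fluorophenyl)carbonyl as well (a number 4.7 percentage points lower from compound 1 to compound 3 (within the scatter)). An aryl on a carbonyl is therefore not required at this position for the reading to stay within the scatter at this one concentration. Nothing available explains this result. Going by these compounds, it remains open whether another group on this nitrogen, such as an acetyl carrying an amine or a longer chain on the sulfonyl, would move the number beyond the scatter.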